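Amino in Place of Hydroxy: Compound 4 Expected Near Compound 3

A few compounds are considered here, and "the series" means these few. Any claim that something is new, unique, unknown or untested is made for them only; others in the source may bear on it.

Three compounds have been measured in an assay on isolated protein for inhibition of Neprilysin (Oryctolagus cuniculus); on this read-out lower numbers stand for stronger inhibition and higher numbers for weaker inhibition:

compound 1, `Cc1ccc([C@H]2CC[C@@H](C(=O)O)N2C(=O)CNC(=O)[C@@H](S)Cc2ccc(O)cc2)cc1`, 5.5 nM
compound 2, `O=C(NCC(=O)N1[C@@H](c2ccccc2O)CC[C@H]1C(=O)O)[C@@H](S)Cc1ccc(O)cc1`, 3.5 nM
compound 3, `O=C(NCC(=O)N1[C@@H](c2ccc(O)cc2)CC[C@H]1C(=O)O)[C@@H](S)Cc1ccc(O)cc1`, 6.36 nM

Compound 3 carries the highest of the three numbers, yet the gaps to the other two, a 1.2-fold higher number from compound 1 to compound 3 (0.06 log units; within the scatter) and a 1.8-fold higher number from compound 2 to compound 3 (0.26 log units; within the scatter), both lie within the scatter, so the three cannot be told apart on this assay.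

Compound 4, `Nc1ccc([C@H]2CC[C@@H](C(=O)O)N2C(=O)CNC(=O)[C@@H](S)Cc2ccc(O)cc2)cc1`, is not yet measured. It differs from compound 3 in one place: amino in place of hydroxy on an aromatic carbon. For the measured compounds named here, two measured steps touch this region. The replacement of methyl by hydroxy on an aromatic carbon, a 1.2-fold higher number from compound 1 to compound 3 (0.06 log units; within the scatter), stayed within the scatter, and the change of 2-hydroxyphenyl to 4-hydroxyphenyl, a 1.8-fold higher number from compound 2 to compound 3 (0.26 log units; within the scatter), stayed within the scatter as well. Going by the values given here, no measured step at this ring has moved this assay beyond the scatter, and no measured compound carries an amino group there, so how that group behaves is unknown. Compound 4 is therefore expected to show a step no larger than the scatter, a 1.2-fold lower number from compound 3 to compound 4 (0.06 log units; within the scatter), in no particular direction. Compound 4 is estimated at 5.5 nM, with a range from 2.5 nM to 12 nM.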

Compound 4, half-maximal inhibitory concentration: 26 nM
Compound 4: the middle estimate sits 4.7-fold (0.67 log units) below what was measured, and the stated range ends below it.
By their numbers in this assay, from the lowest: compounds 2, 1 and 3 (each within the scatter of the next); then compound 4.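

In this assay, for the compounds shown here, this ring position proved not to be indifferent to what it carries: the change from 4-hydroxyphenyl to 4-aminophenyl (  a 4.1-fold higher number from compound 3 to compound 4 (0.61 log units; beyond the scatter)  ) goes beyond the scatter, which no step among compounds 1, 2 and 3 had done. Compound 4 also stands apart from the other two, both against the methyl group of compound 1 (a 4.7-fold higher number from compound 1 to compound 4 (0.67 log units; beyond the scatter)) and against the 2-hydroxyphenyl group of compound 2 (a 7.4-fold higher number from compound 2 to compound 4 (0.87 log units; beyond the scatter)), so among these four compounds the amino group alone separates from the rest while methyl and hydroxy cannot be told apart. Hydroxy and amino match in the computed counts of heavy atoms, hydrogen-bond donors and acceptors and in net charge, so those counts do not separate the two groups, and nothing at hand accounts for the step.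

The compounds shown leave open whether the higher number belongs to the amino group alone or would also come with an acetamide or a dimethylamino group on the same aromatic carbon. They also leave open whether an amine in the place of the hydroxy of compound 2 would give a step of the same kind.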